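Swapping the dichlorophenyl of compound 1 for trifluoromethylphenyl

The source may hold more compounds than are shown below. What is called first, only, known or untested is meant among the compounds shown, and "the series" means these compounds.

Compound 1 `CC(c1ccc(-c2ccccc2)c(F)c1)c1nnc2n1N=C(c1ccc(Cl)cc1Cl)CS2` gives 6900 nM in a functional assay on HCT-116 cells (Homo sapiens) for inhibition, read by sulforhodamine B assay, with a stated time of 72 h (a higher number here means a weaker inhibitor, a lower number a stronger inhibitor), the lowest of the three numbers at hand. Compound 3 `COc1ccc2cc(C(C)c3nnc4n3N=C(c3ccc(F)cc3)CS4)ccc2c1` gives 13100 nM, which lies within the scatter of compound 1, while compound 2 `COc1ccc2cc(C(C)c3nnc4n3N=C(c3ccc(Cl)cc3Cl)CS4)ccc2c1` gives 14000 nM, beyond it. Compound 4 `CC(c1ccc(-c2ccccc2)c(F)c1)c1nnc2n1N=C(c1ccc(C(F)(F)F)cc1)CS2` differs from compound 1 in one place: 4-(trifluoromethyl)phenyl in place of 2,4-dichlorophenyl on a carbon with a double bond to nitrogen. Going by the values given here, the one measured step that bears on this position is a 1.1-fold lower number from compound 2 to compound 3 (0.03 log units; within the scatter), which also exchanged the 2,4-dichlorophenyl for a phenyl carrying a single substituent and left the number within the scatter. The change to compound 4 is of the same kind, so no step beyond the scatter is expected in this assay: a 1.1-fold higher number from compound 1 to compound 4 (0.04 log units; within the scatter). Compound 4 is therefore estimated at 7500 nM, with a range from 3000 nM to 18000 nM.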

Compound 4, half-maximal inhibitory concentration: 6100 nM
Beside the measured number, compound 4's estimate is 1.2-fold (0.09 log units) above it; low and high end bracket the measured number.
By their numbers in this assay, from the lowest: compounds 4, 1, 3 and 2 (each within the scatter of the next, the first and the last beyond it).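

In this assay, the exchange gives a 1.1-fold lower number from compound 1 to compound 4 (0.05 log units; within the scatter), so this position accepts 4-(trifluoromethyl)phenyl, with 10 heavy atoms, in place of 2,4-dichlorophenyl, with 8, without a step beyond the scatter. The earlier compounds shown here showed this only for 4-fluorophenyl and with a different group elsewhere on the core. No measurement at hand accounts for this result.

As far as these compounds go, whether an amine or a carboxylic acid on this phenyl would shift the number remains open. So does the effect of replacing the phenyl with a saturated ring such as cyclohexyl.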